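The compounds below may be only part of what the source reports. "The series", "measured", "known", "first", "only" and "open" are said of these compounds alone.

Compound 1, `C[C@H](Nc1ncnc(N)c1C#N)c1cc(=O)n2cc(F)ccc2c1-c1cc(F)cc(F)c1`, is the reference point. In an ADME assay on microsomes from liver (Homo sapiens), read by LC-MS, using NADPH, with a stated time of 30 min, tested at 1 uM (a higher number here means that more of the compound is left, a lower number that less of the compound is left), compound 1 gives 91%. Compound 2, `C[C@H](Nc1nc(N)nc(N)c1C#N)c1cc(=O)n2cc(F)ccc2c1-c1cc(F)cc(F)c1`, carries the change (amino in place of hydrogen on an aromatic carbon). In this assay compound 2 gives 94%. The step reads a number 3 percentage points higher from compound 1 to compound 2 (within the scatter).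

Compound 3, `C[C@H](Nc1ncnc(N)c1C#N)c1c(C2CC2)c(=O)n2cc(F)ccc2c1-c1ccc(F)cc1`, rests on a different core; the difference between the two cores is not broken down here. In this assay compound 3 gives 93%, which sits within the scatter of both compound 1 and compound 2.

Compound 4, `C[C@H](Nc1nc(N)nc(N)c1C#N)c1c(C2CC2)c(=O)n2cc(F)ccc2c1-c1ccc(F)cc1`, differs from compound 3 by amino in place of hydrogen on an aromatic carbon, the same change as that from compound 1 to compound 2. The step for compound 4 is expected to be a number 2 percentage points higher from compound 3 to compound 4 (within the scatter), resting on the earlier step of a number 3 percentage points higher from compound 1 to compound 2 (within the scatter), which stayed within the scatter. Compound 4 is therefore estimated to give 95%, between 87% and 100%.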

Compound 4, percent of the compound remaining: 86%
Compound 4: middle estimate off by 9 percentage points, on the high side, and the stated range ends above it.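

In this assay the new step reads a number 7 percentage points lower from compound 3 to compound 4 (within the scatter). Set beside the earlier step, it does not differ from it by more than repeated measurements allow: the same change on two cores in this assay, a number 3 percentage points higher (within the scatter) from compound 1 to compound 2 and a number 7 percentage points lower (within the scatter) from compound 3 to compound 4, 10 percentage points apart, within the scatter of two such steps This gives no sign that the amino group behaves differently on the two cores, but with only two pairs, both within the scatter, it does not show that the change carries over reliably or that it has any effect on either core.

The compounds shown leave open how a methylamino or a methyl group, set on the aromatic carbon between two ring nitrogen atoms, would read in this assay. They also leave open which of the differences between the two cores, if any, bears on the step.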